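Cytotoxicity of aminoquinoline analogues: toward compound 4

The source may report more compounds than this note shows. Statements on the series, on what has been measured and on what is new or still open speak of the compounds shown alone.

Compound 1 `c1ccc(Oc2ccc3c(NCCCNCc4ccco4)ccnc3c2)cc1`: 15200 nM
Compound 2 `CCC(CC)c1ccc2c(NCCCNCc3cccc(OC)c3O)ccnc2c1`: 410 nM
Compound 3 `CCC(CC)c1ccc2c(NCCCNCc3cc(F)ccc3OC)ccnc2c1`: 7860 nM

In an ADME assay on HepG2 cells (Homo sapiens) for cytotoxicity, read by luminescence, CellTiter-Glo and ATP content, with a stated time of 72 h (on this read-out lower numbers stand for an effect already at smaller amounts and higher numbers for an effect only at larger amounts of compound), compound 2 sits at the lowest number of the three; compound 3 lies at a 19-fold higher number from compound 2 to compound 3 (1.28 log units; beyond the scatter), while compound 1, which differs from compound 2 in two places, shows a much higher value. The unmeasured compound 4 `COc1cccc(CNCCCNc2ccnc3cc(Cc4ccc(F)cc4Cl)ccc23)c1O` is compound 2 with 2-chloro-4-fluorobenzyl in place of pentan-3-yl on an aromatic carbon. Within the data shown here, no measured step touches this position; the only single-place step, from compound 2 to compound 3, concerns the other end of the molecule and so gives no guide here. The step is therefore expected to stay modest and uncertain in direction, a 1.7-fold higher number from compound 2 to compound 4 (0.23 log units; within the scatter). Compound 4 is estimated at 700 nM, with a range from 150 nM to 3500 nM in this assay.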

Compound 4, half-maximal effective concentration: 2350 nM
Estimate against measurement, compound 4: 3.4-fold (0.53 log units) below, within the range that was stated.
By their numbers in this assay, from the lowest: compound 2; then compound 4; then compounds 3 and 1 (each within the scatter of the next).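

In this assay the change from pentan-3-yl to 2-chloro-4-fluorobenzyl on this aromatic carbon gives a 5.7-fold higher number from compound 2 to compound 4 (0.76 log units; beyond the scatter) and so shows that this position, untouched by the earlier single-place step, responds beyond the scatter. The entering group adds one six-membered aromatic ring of carbon only, while neither group carries hydrogen-bond donors or acceptors. No supporting measurement accounts for the shift. The compounds shown leave open whether the ring itself or its chlorine and fluorine carry the step, and how a plain benzyl or a piperidine on this carbon would read.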